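Swapping Fluoro for Chloro on a Shared Core

The source may report more compounds than this note shows. Statements on the series, on what has been measured and on what is new or still open speak of the compounds shown alone.

Compound 1, `C/C(=N/NC(=O)Nc1nc(-c2ccc(F)cc2)cc(-c2ccc([N+](=O)[O-])cc2)n1)c1ccc(C)cc1`: 300 mg/kg
Compound 2, `C/C(=N/NC(=O)Nc1nc(-c2ccc(C)cc2)cc(-c2ccc(F)cc2)n1)c1ccc([N+](=O)[O-])cc1`: 300 mg/kg
Compound 3, `C/C(=N/NC(=O)Nc1nc(-c2ccc(C)cc2)cc(-c2ccc(F)cc2)n1)c1ccc(Cl)cc1`: 300 mg/kg
Compound 4, `C/C(=N/NC(=O)Nc1nc(-c2ccc(C)cc2)cc(-c2ccc(Cl)cc2)n1)c1ccc(Cl)cc1`: not yet measured

Of the compounds shown here, three built on the same core have been tested in a functional assay on the whole organism (strain Albino) with Mus musculus as the target, with a stated time of 4 h; a higher number here means that more compound is needed for the effect, a lower number that less compound is needed. In this assay compound 1 gives 300 mg/kg, compound 2 gives 300 mg/kg, and compound 3 gives 300 mg/kg. Compound 3 therefore stands level with compounds 1 and 2, with no separation beyond the scatter among the three.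

Compound 4 differs from compound 3 in one place: chloro in place of fluoro on an aromatic carbon. For the measured compounds named here, the only measured step that speaks to a change of this kind is the one from compound 2 to compound 3, where a different halogen-type substitution on an aromatic carbon gave no change at the digits printed from compound 2 to compound 3 (within the scatter). That step suggests that exchanging one small aromatic substituent for another does not move the dose here. The expectation for compound 4 is accordingly no step beyond the scatter, no change at the digits printed from compound 3 to compound 4 (within the scatter). Compound 4 is estimated at 300 mg/kg, with a range from 150 mg/kg to 600 mg/kg.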

Compound 4, dose for half-maximal effect: 300 mg/kg
Estimate against measurement, compound 4: no gap at the digits printed; measured number inside the range.
By their numbers in this assay, from the lowest: compounds 1, 2, 3 and 4 (each within the scatter of the next).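

Exchanging 4-fluorophenyl for 4-chlorophenyl on the shared core gives, in this assay, no change at the digits printed from compound 3 to compound 4 (within the scatter). This is a direct reading at the position para to a large group, whereas the earlier step, no change at the digits printed from compound 2 to compound 3 (within the scatter), concerned a substituent on a different aromatic ring, so the two halogens can now be compared at this position with everything else in the molecule held the same. No measurement offers an explanation for this result.

Going by these compounds, all four compounds share the same printed value, so it remains open whether any change at this position can separate compounds in this assay. An amine, a carboxylic acid or a longer chain in place of the halogen would test this with a group quite unlike fluoro or chloro.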